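A phenoxy group on the core of compound 1

A few compounds are considered here, and "the series" means these few. Any claim that something is new, unique, unknown or untested is made for them only; others in the source may bear on it.

Among the compounds with values here, in a functional assay on HL-60 cells (Homo sapiens) for inhibition, read by resazurin assay, with a stated time of 72 h (on this read-out higher numbers stand for weaker inhibition and lower numbers for stronger inhibition), compound 1 `COc1cc(N2C(=O)CC2c2ccc(SC)cc2)cc(OC)c1OC` gives 69 nM and holds the lower of the two numbers measured so far. Compound 2 `CCSc1ccc(C2CC(=O)N2c2cc(OC)c(OC)c(OC)c2)cc1` gives 204 nM in this assay and carries methyl in place of hydrogen on a saturated chain carbon bound to a sulfur. Within the data shown here, that change is the only measured step, a 3.0-fold higher number from compound 1 to compound 2 (0.47 log units; beyond the scatter) and so a modest move towards weaker inhibition. Compound 3 `COc1cc(N2C(=O)C(Oc3ccccc3)C2c2ccc(SC)cc2)cc(OC)c1OC` is still unmeasured. Among the measured compounds shown here, it differs from compound 1 by phenoxy in place of hydrogen on a saturated ring carbon as its one change, phenoxy in place of hydrogen on a saturated ring carbon. For the measured compounds named here, no measured compound carries any group on that ring carbon, so the data offer only indirect guidance. Going by the values given here, the single step from the sulfur chain, a 3.0-fold higher number from compound 1 to compound 2 (0.47 log units; beyond the scatter) as measured, suggests that additions to compound 1 need not be tolerated freely. A step of similar or somewhat larger size towards a higher number is therefore expected, with wide uncertainty. The estimate amounts to a 2.2-fold higher number from compound 1 to compound 3 (0.34 log units; beyond the scatter) as the expected step. Compound 3 is expected at 150 nM with an estimated range of 25 nM to 1000 nM in this assay for now.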

Compound 3, half-maximal inhibitory concentration: 388 nM
Compound 3: middle estimate off by 2.6-fold (0.41 log units), on the low side; the range from low to high includes it.
By their numbers in this assay, from the lowest: compound 1; then compounds 2 and 3 (each within the scatter of the next).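

In this assay, the saturated ring carbon two ring bonds from the ring nitrogen now has its first measured substituent, and phenoxy in place of hydrogen there gives a 5.6-fold higher number from compound 1 to compound 3 (0.75 log units; beyond the scatter) on the core of compound 1. The position therefore responds to this group, which brings 7 heavy atoms and one six-membered aromatic ring, with a move towards weaker inhibition that lies beyond the scatter, yet compound 3 still reads 388 nM and so keeps inhibition in the same assay. Nothing available explains the size of this step or separates the part played by the ether oxygen from that of the aromatic ring.

The compounds shown leave open whether a smaller group on this carbon, such as methoxy or hydroxyl, would stay closer to compound 1 than phenoxy does. They also leave open how an amine or a benzyl group would read at the same place, and whether a substituted phenoxy ring would move the number in either direction.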